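A few compounds are considered here, and "the series" means these few. Any claim that something is new, unique, unknown or untested is made for them only; others in the source may bear on it.

Measured so far in a functional assay on HepG2 cells (Homo sapiens) for cytotoxicity, read by MTT assay, with a stated time of 24 h; a higher number here means a weaker inhibitor, a lower number a stronger inhibitor:

- compound 1 `COc1cc(/C=C2\CN(S(=O)(=O)c3ccc(F)cc3)C/C(=C\c3cc(OC)c(OC)c(OC)c3)C2=O)cc(OC)c1OC` gives 4200 nM
- compound 2 `CC(=O)Nc1ccc(S(=O)(=O)N2C/C(=C\c3cccc([N+](=O)[O-])c3)C(=O)/C(=C/c3cccc([N+](=O)[O-])c3)C2)cc1` gives 7140 nM
- compound 3 `COc1cc(/C=C2\CN(S(=O)(=O)c3ccc(NC(C)=O)cc3)C/C(=C\c3cc(OC)c(OC)c(OC)c3)C2=O)cc(OC)c1OC` gives 3890 nM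

Compound 3 has no clear place of its own among these numbers, since all three values lie within the usual scatter of one another. The next structure is compound 4 `COc1cc(/C=C2\CN(S(=O)(=O)c3ccc(NC(C)=O)cc3)C/C(=C\c3ccc(C#N)cc3)C2=O)cc(OC)c1OC`, which keeps the core and the acetamido group of compound 3 but exchanges one of its trimethoxyphenyl groups: 4-cyanophenyl in place of 3,4,5-trimethoxyphenyl on a double-bonded chain carbon bound to a double-bonded ring carbon. In words, 4-cyanophenyl stands in place of 3,4,5-trimethoxyphenyl on a double-bonded chain carbon bound to a double-bonded ring carbon.

Only one measured step links two of these compounds: a 1.1-fold lower number from compound 1 to compound 3 (0.03 log units; within the scatter), with acetamido in place of fluoro on an aromatic carbon. That step lies within the scatter, but it concerns a different part of the molecule, so it bears on this change only indirectly. For the measured compounds named here, no measured step isolates the trimethoxyphenyl group. The nearest evidence is compound 2, which has nitro-bearing rings in place of both trimethoxyphenyl groups and gives 7140 nM, still within the scatter of the value for compound 3. A modest shift at most is therefore expected, and any drift would be toward a higher number.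

The expected change is a 1.3-fold higher number from compound 3 to compound 4 (0.11 log units; within the scatter), which would probably not stand clear of the scatter. The estimate for compound 4 is 5000 nM, with an expected range from 2200 nM to 11500 nM.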

Compound 4, half-maximal inhibitory concentration: 2890 nM
Compound 4: middle estimate off by 1.7-fold (0.24 log units), on the high side; measured number inside the range.
By their numbers in this assay, from the lowest: compounds 4, 3, 1 and 2 (each within the scatter of the next, the first and the last beyond it).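

For the compounds shown here, compound 4 gives the first direct reading at this position: in this assay, the exchange of 3,4,5-trimethoxyphenyl for 4-cyanophenyl amounts to a 1.3-fold lower number from compound 3 to compound 4 (0.13 log units; within the scatter), so the assay does not separate the two compounds. This holds even though the two groups differ in what is counted on them: the one that leaves has 12 heavy atoms and 3 hydrogen-bond acceptors, and the one that enters has 8 heavy atoms, 1 hydrogen-bond acceptor and a triple bond. On a double-bonded chain carbon bound to a double-bonded ring carbon, one of these aromatic groups can therefore stand in for the other with no readable change in this assay, and no measurement at hand offers an explanation for this.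

As far as these compounds go, it remains open whether an aromatic ring is needed here at all, a question that a plain ethyl chain could address, and how a ring carrying an amine or a carboxylic acid would behave at this position. Also open, from the compounds shown here alone, is what happens when the second 3,4,5-trimethoxyphenyl group of compound 4 is exchanged for 4-cyanophenyl as well.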